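Aryl Piperazines on a Shared Core: Toward Compound 4

The compounds below may be only part of what the source reports. "The series", "measured", "known", "first", "only" and "open" are said of these compounds alone.

Compound 1, `CC(C)N1CCN(Cc2csc(N)c2C(=O)c2ccc(Cl)cc2)CC1`, in a functional assay on CHO cells with adenosine receptor A1 (Homo sapiens) as the target, read by cAMP accumulation and immunoassay, with a stated time of 6 min, tested at 0.1 uM (on this read-out higher numbers stand for a weaker effect at the one concentration tested and lower numbers for a stronger effect), gives 3.6%.
Compound 2, `Nc1scc(CN2CCN(c3ccc(F)cc3Cl)CC2)c1C(=O)c1ccc(Cl)cc1`, gives -6.2%.
Compound 3, `Nc1scc(CN2CCN(c3cccc(F)c3)CC2)c1C(=O)c1ccc(Cl)cc1`, gives -37%.

Among the three compounds measured, compound 3 stands lowest; its nearest neighbour is compound 2, and the gap between them, a number 30.8 percentage points lower from compound 2 to compound 3 (beyond the scatter), lies beyond the scatter, as does the still wider gap a number 40.6 percentage points lower from compound 1 to compound 3 (beyond the scatter). Compound 4, `Nc1scc(CN2CCN(c3ccc(F)c(Cl)c3)CC2)c1C(=O)c1ccc(Cl)cc1`, has not yet been measured. It differs from compound 3 by 3-chloro-4-fluorophenyl in place of 3-fluorophenyl on an amine nitrogen in a ring.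

Going by the values given here, the steps that bear on this change are those that alter the group on the same ring nitrogen. The step of a number 9.8 percentage points lower from compound 1 to compound 2 (within the scatter) was small, whereas a number 30.8 percentage points lower from compound 2 to compound 3 (beyond the scatter) was large, so the arrangement of halogens on this phenyl has shifted the read-out considerably within these three compounds. Compound 4 carries a halogen pattern that shares the 4-fluorine of compound 2 and the 3-position of compound 3, so its value is expected to fall between those two, giving a step of a number 13 percentage points higher from compound 3 to compound 4 (beyond the scatter) that is expected to be modest and upward. Compound 4 is therefore estimated at -24%, within a range of -48% to 2%.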

Compound 4, a percentage reported as activity, at one concentration (the size of the read-out at that concentration, not a potency): -21%
Compound 4: middle estimate off by 3 percentage points, on the low side; the range from low to high includes it.
By their numbers in this assay, from the lowest: compound 3; then compound 4; then compounds 2 and 1 (each within the scatter of the next).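

In this assay, 3-chloro-4-fluorophenyl in place of 3-fluorophenyl gives a step of a number 16 percentage points higher from compound 3 to compound 4 (beyond the scatter) and so leaves 3-fluorophenyl with the lowest number of the four compounds, while 2-chloro-4-fluorophenyl in place of 3-chloro-4-fluorophenyl separates two phenyl groups that carry the same halogens, with the step read in the listed direction as a number 14.8 percentage points lower from compound 2 to compound 4 (beyond the scatter) and thus showing that the place of the chlorine alone changes the read-out, which the earlier compounds could not show. Set against isopropyl, the step of a number 24.6 percentage points lower from compound 1 to compound 4 (beyond the scatter) shows that 3-chloro-4-fluorophenyl moves the number beyond the scatter, where 2-chloro-4-fluorophenyl did not. Nothing given here accounts for these shifts.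

The compounds shown leave open how the read-out would respond to a methoxy group or a nitrile on this phenyl, or to a longer chain on the ring nitrogen in place of the phenyl. All four numbers also come from a single concentration in this assay and so say nothing of potency.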